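The compounds below may be only part of what the source reports. "The series", "measured", "known", "first", "only" and "open" are said of these compounds alone.

In a functional assay on SW-620 cells (Homo sapiens) for inhibition, read by MTT assay, with a stated time of 72 h (on this read-out higher numbers stand for weaker inhibition and lower numbers for stronger inhibition), the measured compounds stand as follows:
compound 1 `COc1cc(Oc2cccc(Nc3ccccc3)c2)cc(OC)c1CN[C@H](C)c1ccccc1` gives 18700 nM;
compound 2 `CCN1CCN(Cc2c(OC)cc(Oc3cccc(Nc4ccccc4)c3)cc2OC)CC1` gives only the limit > 20000 nM;
compound 3 `COc1cc(Oc2cccc(Nc3ccccc3)c2)cc(OC)c1CN(C)C` gives only the limit > 20000 nM.

Compound 3 thus carries a limit of this assay rather than a number. Compound 2 likewise sits at a limit, so that (the limit of > 20000 nM in this assay, at which 2 of the 3 values shown sit). The step from compound 3 to compound 4 `COc1cc(Oc2cccc(Nc3ccccc3)c2)cc(OC)c1CCO` is hydroxymethyl in place of dimethylamino on a saturated chain carbon bound to an aromatic carbon. Every measured step changes the group on that same saturated chain carbon bound to an aromatic carbon: an at least 1.0-fold higher number from compound 1 to compound 2 (0.02 log units; that floor lies within the scatter), an at least 1.0-fold higher number from compound 1 to compound 3 (0.02 log units; that floor lies within the scatter), and a step that the two limits leave unreadable from compound 2 to compound 3. None of them moved this assay beyond its scatter, and two of the three values end at the limit. Compound 4 exchanges one such group for another on that carbon, so no step beyond the scatter is expected, and the expected step is a step that the limit leaves unreadable from compound 3 to compound 4. Compound 4 is expected to stay near or at the limit. Compound 4 is therefore estimated at 22000 nM, with a range from 8000 nM to 60000 nM.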

Compound 4, half-maximal inhibitory concentration: > 20000 nM
Compound 4: no number, only a limit; the forecaster's own chance of this, stated with the estimate: 70%; the middle value lies beyond the limit too.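

The change on the saturated chain carbon bound to an aromatic carbon now reaches a group without nitrogen: in this assay, hydroxymethyl replaces dimethylamino, and compound 4 gives > 20000 nM, which is a limit and not a number. The steps to compound 4 from compound 2 and compound 3 cannot be read, and the only readable one is an at least 1.0-fold higher number from compound 1 to compound 4 (0.02 log units; that floor lies within the scatter). The limit therefore now holds for a group that is not an amine as well as for the amines of compound 2 and compound 3: the limit of > 20000 nM in this assay, at which 3 of the 4 values shown sit.

How far compound 2, compound 3 and compound 4 lie beyond the limit remains open, so any differences among these groups stay hidden. Also open, on these data alone, is whether a carboxylic acid, an amide or a longer chain on this carbon would give a readable number in this assay.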